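A few compounds are considered here, and "the series" means these few. Any claim that something is new, unique, unknown or untested is made for them only; others in the source may bear on it.

Measured so far in a functional assay on A549 cells (Homo sapiens) for antiproliferative activity, read by MTT assay, with a stated time of 72 h; on this read-out lower numbers stand for stronger inhibition and higher numbers for weaker inhibition:
- compound 1 `COc1cc(C(=O)c2sc3ccccc3c2-c2ccc(C)cc2)cc(OC)c1OC`: 7800 nM
- compound 2 `COc1cc(C(=O)c2sc3ccccc3c2Nc2ccccc2)cc(OC)c1OC`: 3000 nM

Of these two compounds, compound 2 has the lower number, and so the stronger inhibition, in this assay. Compound 3 `COc1cc(C(=O)c2sc3ccccc3c2Nc2ccc(Cl)cc2)cc(OC)c1OC` has not yet been measured. It differs from compound 2 by a single change: chloro in place of hydrogen on an aromatic carbon. In words, this is chloro in place of hydrogen on an aromatic carbon, turning the anilino group into (4-chlorophenyl)amino.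

Within the data shown here, only one measured step is available, a 2.6-fold lower number from compound 1 to compound 2 (0.41 log units; beyond the scatter). It is a modest step, and it comes from putting anilino in place of 4-methylphenyl, so it bears on the new change only indirectly. Among the measured compounds shown here, no measured compound carries a chloro group, so the data give no direct guide to its size or direction. The expectation therefore stays anchored on compound 2 at 3000 nM, and no shift beyond the scatter is expected in this assay. The expected step is a 1.2-fold lower number from compound 2 to compound 3 (0.08 log units; within the scatter). For compound 3 the estimated value is 2500 nM, with an expected range from 800 nM to 8000 nM.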

Compound 3, half-maximal inhibitory concentration: 3100 nM
Beside the measured number, compound 3's estimate is 1.2-fold (0.09 log units) below it, within the range that was stated.
By their numbers in this assay, from the lowest: compounds 2 and 3 (each within the scatter of the next); then compound 1.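

In this assay, chloro in place of hydrogen on an aromatic carbon, para to a large group, gives a 1.0-fold higher number from compound 2 to compound 3 (0.01 log units; within the scatter), so this position accepts a chloro group with no change that this read-out can resolve. The earlier compounds shown here showed only that anilino in place of 4-methylphenyl lowers the number; compound 3 shows that the link holds with the chloro group present, since (4-chlorophenyl)amino in place of 4-methylphenyl gives a 2.5-fold lower number from compound 1 to compound 3 (0.40 log units; beyond the scatter). Nothing in the data at hand speaks to what lies behind either step.

The compounds shown leave open whether a different group at this same position, such as methoxy, an amine or a carboxylic acid, would move the number beyond the scatter, or whether the position simply makes little difference to the result in this assay. Among these compounds, they also leave open what a chloro group would do on another carbon of this six-membered aromatic ring, since compound 3 is the only compound here that carries one.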